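Swapping a ring amine for a branched chain amine

The compounds below may be only part of what the source reports. "The series", "measured", "known", "first", "only" and "open" are said of these compounds alone.

Of the compounds shown here, three built on one shared core have been measured in a physicochemical assay for lipophilicity; a lower number here means a more polar compound, a higher number a more lipophilic compound. Compound 1 `Cc1c(N(C)C)c(=O)n(C)c(=O)n1-c1ccc(Cl)cc1` gives 2.32. Compound 2 `CCCNc1c(C)n(C)c(=O)n(-c2ccccc2)c1=O` gives 1.2. Compound 3 `Cc1c(N2CCCC2)c(=O)n(-c2ccccc2)c(=O)n1C` gives 2.26, which places it close to compound 1 and well apart from compound 2. Among the measured compounds shown here, the one step seen so far, a number 1.06 log units higher from compound 2 to compound 3 (beyond the scatter), is large. Compound 4 `Cc1c(NCC(C)C)c(=O)n(-c2ccccc2)c(=O)n1C` is not yet measured; it differs from compound 3 by isobutylamino in place of pyrrolidin-1-yl on an aromatic carbon. This is nearly the reverse of the step from compound 2 to compound 3, with one more carbon in the entering chain, so a drop smaller than that step is expected, about a number 0.66 log units lower from compound 3 to compound 4 (beyond the scatter). Compound 4 is therefore estimated at 1.6, between 1.1 and 2.1.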

Compound 4, partition coefficient: 1.48
The estimate for compound 4 lay 0.12 log units above the measured number; low and high end bracket the measured number.
By their numbers in this assay, from the lowest: compounds 2 and 4 (each within the scatter of the next); then compounds 3 and 1 (each within the scatter of the next).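

In this assay, isobutylamino in place of pyrrolidin-1-yl gives a number 0.78 log units lower from compound 3 to compound 4 (beyond the scatter), so on this aromatic carbon the open chain and the ring differ clearly, although both groups hold 5 heavy atoms. Adding a methyl to the chain leaves the reading within the scatter, with a number 0.28 log units higher from compound 2 to compound 4 (within the scatter). No measurement here explains either step. As far as these compounds go, it remains open whether the gap follows the ring itself or the amine hydrogen, which only the chain carries. Diethylamino, an open chain without that hydrogen, and piperidin-1-yl, a larger ring, would help separate the two.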